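Swapping Trifluoromethyl for Methyl on a Coumarin Inhibitor

The source may report more compounds than this note shows. Statements on the series, on what has been measured and on what is new or still open speak of the compounds shown alone.

Measured compounds:
compound 1 `O=c1cc(Cn2ccnc2)c2ccc(OCc3cccc(C(F)(F)F)c3)cc2o1` gives 20 nM
compound 2 `CCCOc1ccc(COc2ccc3c(Cn4ccnc4)cc(=O)oc3c2)cc1` gives 63 nM

In an assay on V79MZh11B1 cells for inhibition of cytochrome P450 11B1, mitochondrial (Homo sapiens), read by HPLC, with a stated time of 25 min (a lower number here means a stronger inhibitor, a higher number a weaker inhibitor), compound 1 gives the lowest of the two numbers; the nearest neighbour is compound 2, whose value lies beyond the usual scatter above it. Compound 3 `Cc1cccc(COc2ccc3c(Cn4ccnc4)cc(=O)oc3c2)c1` shares the core of compound 1 and differs from it in one place: methyl in place of trifluoromethyl on an aromatic carbon. Going by the values given here, no step between two measured compounds matches this exact exchange, so the expectation rests on the two values alone. Because compound 2 gives 63 nM with a different group on the outer ring, a move away from trifluoromethyl is expected to cost some potency, but only modestly. The step from compound 1 to compound 3 is therefore estimated as a 2.0-fold higher number from compound 1 to compound 3 (0.30 log units; within the scatter). For compound 3 the expected value is 40 nM, with a likely range from 15 nM to 110 nM.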

Compound 3, half-maximal inhibitory concentration: 45 nM
Compound 3: middle estimate off by 1.1-fold (0.05 log units), on the low side, within the range that was stated.
By their numbers in this assay, from the lowest: compound 1; then compounds 3 and 2 (each within the scatter of the next).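

In this assay, going by these compounds alone, this is the first direct reading of the exchange at this aromatic carbon, meta to a large group: methyl in place of trifluoromethyl gives a 2.3-fold higher number from compound 1 to compound 3 (0.35 log units; beyond the scatter) for this single change. The step is modest, and compound 3 gives 45 nM without any fluorine on the outer ring, so trifluoromethyl is favoured here but is not required for inhibition at this level. Nothing measured here explains the size of this step.

The compounds shown leave open how other groups would fare on this same carbon, such as a chlorine, a methoxy or a nitrile. They also leave open whether methyl and trifluoromethyl would differ by a similar step with the rest of the molecule changed.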